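Three Measured Compounds and One Expected Value

The source may report more compounds than this note shows. Statements on the series, on what has been measured and on what is new or still open speak of the compounds shown alone.

Compound 1, `CCCCCCCCCCn1cc(-c2nc3ccccc3cc2CCCC)nn1`, in a functional assay on HeLa cells (Homo sapiens) for cytotoxicity, read by MTT assay, with a stated time of 24 h (a higher number here means a weaker inhibitor, a lower number a stronger inhibitor), gives only a limit of the assay, > 100 ug/mL.
Compound 2, `CCCCCCCCCCn1cc(-c2nc3ccccc3cc2CCC)nn1`, in this assay likewise gives only a limit, > 100 ug/mL.
Compound 3, `CCc1cc2ccccc2nc1-c1cn(-c2ccc(F)cc2)nn1`, in this assay also gives only a limit, > 100 ug/mL.

Compound 1 and compound 2 share a core and differ in one place: methyl in place of hydrogen on a saturated chain carbon, three bonds along the chain from an aromatic carbon. The step this makes in this assay is a step that the two limits leave unreadable from compound 2 to compound 1, so its size cannot be read, since both compounds sit at the same limit. The core of compound 3 is a different one, and the difference between the two cores is not broken down here.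

Compound 4, `CCCc1cc2ccccc2nc1-c1cn(-c2ccc(F)cc2)nn1`, is not yet measured. It differs from compound 3 in one place: methyl in place of hydrogen on a saturated chain carbon, two bonds along the chain from an aromatic carbon. This is the same kind of change as that from compound 2 to compound 1, but not the same. The place there is three bonds along the chain from an aromatic carbon, while here it is two bonds along the chain from an aromatic carbon.

In this assay the step from compound 3 to compound 4 is expected to be a step that the limit leaves unreadable from compound 3 to compound 4. This expectation rests on (the limit of > 100 ug/mL in this assay, at which 3 of the 3 values shown sit), which shows that the one related change with a measured pair moved nothing readable, and that every compound shown, compound 1, compound 2 and compound 3 alike, sits at that limit. Compound 4 is therefore estimated at 150 ug/mL, within a range from 60 ug/mL to 400 ug/mL, and most likely the assay will again report only a limit.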

Compound 4, half-maximal inhibitory concentration: > 100 ug/mL
Compound 4 gave a limit, no number; the forecaster's own chance of this, stated with the estimate: 80%; the middle value lies beyond the limit too.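

In this assay compound 4 gives only a limit of the assay, > 100 ug/mL. Going by these compounds alone, compound 3 gives a limit as well, so no step between compound 3 and compound 4 can be read. The compounds shown leave open how strongly any of them acts in this assay, and whether methyl in place of hydrogen on the chain changes that at all: the limit of > 100 ug/mL in this assay, at which 4 of the 4 values shown sit.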